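The source may hold more compounds than are shown below. What is called first, only, known or untested is meant among the compounds shown, and "the series" means these compounds.

Measured compounds:
Compound 1, `COc1ccc(C2=NN(c3ccccc3)C(c3ccc(C)cc3)C2S(=O)(=O)CC2=NCCO2)cc1`: 67.7%
Compound 2, `COc1ccc(C2=NN(c3ccccc3)C(c3ccc(C)cc3)C2S(=O)(=O)CC2=NCCS2)cc1`: 47.9%
Compound 3, `Cc1ccc(-c2c[nH]nc2S(=O)(=O)CC2=NCCS2)cc1`: "not active" (no number reported)

All three were tested in a functional assay, tested at 100 ug/mL; a higher number here means a stronger effect of the compound at the concentration tested, a lower number a weaker effect. Compound 1 and compound 2 share one core and differ in a single place, where compound 1 carries a group of 5 heavy atoms (3 carbon, 1 nitrogen, 1 oxygen; one five-membered non-aromatic ring with 2 hetero atoms) in place of a group of 5 heavy atoms (3 carbon, 1 nitrogen, 1 sulfur; one five-membered non-aromatic ring with 2 hetero atoms), on a saturated chain carbon bound to a sulfonyl sulfur. That swap made a step of a number 19.8 percentage points higher from compound 2 to compound 1 (beyond the scatter), a modest gain that lies outside the usual scatter of this kind of measurement.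

Compound 3 rests on a different and smaller core, and the difference between the two cores is not broken down here. In this assay compound 3 showed no activity that could be put into a number.

Compound 4, `Cc1ccc(-c2c[nH]nc2S(=O)(=O)CC2=NCCO2)cc1`, has not yet been measured. It relates to compound 3 exactly as compound 1 relates to compound 2: the change is a group of 5 heavy atoms (3 carbon, 1 nitrogen, 1 oxygen; one five-membered non-aromatic ring with 2 hetero atoms) in place of a group of 5 heavy atoms (3 carbon, 1 nitrogen, 1 sulfur; one five-membered non-aromatic ring with 2 hetero atoms), on a saturated chain carbon bound to a sulfonyl sulfur, in the same place and of the same description, so it is the same change. For the measured compounds named here, whether a gain of similar size will appear on the second core is unknown, since the only evidence for the swap comes from compound 1 and compound 2, whose core is larger. If the step repeats on this core, compound 4 would still start from a compound with no measurable activity, so only a small read-out is expected. The estimate for compound 4 in this assay is 22%, with a likely range from 5% to 45%.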

Compound 4, a percentage reported as activity, at one concentration (the size of the read-out at that concentration, not a potency): 65.5%
For compound 4 the middle estimate is 43.5 percentage points below the measured one, outside the stated range (above it).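

In this assay, for the compounds shown here, compound 4 gives 65.5% but compound 3 has no number, so no step between compound 3 and compound 4 can be read. No measurement shown here bears on a cause for this result. Still open, going by these compounds, is how the oxygen-containing ring and the sulfur-containing ring compare on the core of compound 3 and compound 4 in numbers.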